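Working notes: ring substitution at the detection limit

A few compounds are considered here, and "the series" means these few. Any claim that something is new, unique, unknown or untested is made for them only; others in the source may bear on it.

compound 1 `COc1ccccc1-c1n[nH]cc1N1CCNCC1` — in an assay on isolated protein for binding affinity to 5-hydroxytryptamine receptor 3A (Homo sapiens) (a lower number here means a stronger inhibitor, a higher number a weaker inhibitor), compound 1 gives > 10000 nM, which is a limit of the assay.
compound 2 `c1ccc(-c2n[nH]cc2N2CCNCC2)cc1` — in this assay compound 2 gives > 10000 nM, which is a limit of the assay.
compound 3 `Clc1ccccc1-c1n[nH]cc1N1CCNCC1` — in this assay compound 3 gives > 10000 nM, which is a limit of the assay.

Compound 3 therefore stands only at a limit of this assay, with no number behind it. Among the compounds with values here, the two further values are limits as well, so that the limit of > 10000 nM in this assay, at which 3 of the 3 values shown sit, describes every value measured so far. None of the steps between the measured compounds can be read: a step that the two limits leave unreadable from compound 1 to compound 2, a step that the two limits leave unreadable from compound 1 to compound 3 and a step that the two limits leave unreadable from compound 2 to compound 3 all run between two limits and give no size. Changing methoxy to hydrogen or to chloro on the aromatic carbon, or hydrogen to chloro, thus left every compound at the limit.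

Compound 4 `Fc1ccccc1-c1n[nH]cc1N1CCNCC1` is the next member. It differs from compound 3 in one place: fluoro in place of chloro on an aromatic carbon. Within the data shown here, the steps that bear on this change are a step that the two limits leave unreadable from compound 1 to compound 3 and a step that the two limits leave unreadable from compound 2 to compound 3, both unreadable, so no direction or size can be taken from them.

The expectation for compound 4 in this assay is therefore a step that the limit leaves unreadable from compound 3 to compound 4, with the value most likely reported as a limit once more. Compound 4 is estimated at 20000 nM, in the range 5000 nM to 80000 nM.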

Compound 4, inhibition constant: 1960 nM
For compound 4 the middle estimate is 10-fold (1.01 log units) above the measured one, and the stated range ends above it.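

Fluoro is the first group at this place on the aromatic ring, ortho to a large group, to bring a compound off the limit in this assay, with chloro giving way to fluoro as (an at least 5.1-fold lower number from compound 3 to compound 4 (0.70 log units; beyond the scatter)). The same holds when fluoro is compared with hydrogen (an at least 5.1-fold lower number from compound 2 to compound 4 (0.70 log units; beyond the scatter)) and with methoxy (an at least 5.1-fold lower number from compound 1 to compound 4 (0.70 log units; beyond the scatter)). The place therefore responds to which group sits on it: chloro and fluoro each count one heavy atom, with no ring, no hydrogen-bond donor or acceptor and no net charge, yet only the compound with fluoro gives a readable value.

As far as these compounds go, whether a methyl, a nitrile or a trifluoromethyl group at the same place would also leave the limit remains open. The true size of all three steps is open as well, and the steps among compound 1, compound 2 and compound 3 cannot be read, as every comparison rests on the same limit: the limit of > 10000 nM in this assay, at which 3 of the 4 values shown sit.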